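The source may report more compounds than this note shows. Statements on the series, on what has been measured and on what is new or still open speak of the compounds shown alone.

Measured compounds:
compound 1 `COc1cccc(/C=C2\CCC/C(=C\c3ccccc3Br)C2=O)c1OC` gives 9700 nM
compound 2 `COc1ccc(/C=C2\CCC/C(=C\c3cccc(OC)c3OC)C2=O)c(OC)c1` gives > 20000 nM
compound 3 `COc1ccc(/C=C2\CCC/C(=C\c3ccc(Cl)cc3)C2=O)cc1OC` gives 6300 nM

The three compounds share one core and differ only in the aryl groups attached to it. In a functional assay on MCF7 cells (Homo sapiens) for cytotoxicity, read by MTT assay, with a stated time of 72 h (a lower number here means a stronger inhibitor, a higher number a weaker inhibitor), compound 3 gives 6300 nM, the lowest of the two numbers read out. Its nearest neighbour is compound 1, whose value of 9700 nM lies within the usual scatter of compound 3, so no order can be drawn between the two. Compound 2 reaches only a limit of the assay, > 20000 nM, and no number is known for it; this is the limit described as the limit of > 20000 nM in this assay, at which 1 of the 3 values shown sits.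

The unmeasured compound 4 `COc1ccc(/C=C2\CCC/C(=C\c3cc(Cl)cc(Cl)c3)C2=O)cc1OC` arises from compound 3 by a single change: 3,5-dichlorophenyl in place of 4-chlorophenyl on a double-bonded chain carbon bound to a double-bonded ring carbon. Among the compounds with values here, the two measured numbers give no step that tracks this kind of change, so there is no measured guide to its size or direction. With no such guide, the expected step from compound 3 to compound 4 is none beyond the scatter, and the estimate of a 1.0-fold higher number from compound 3 to compound 4 (0.01 log units; within the scatter) reflects that. Compound 4 is accordingly expected to give about 6500 nM in this assay, with a range from 2500 nM to 17000 nM.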

Compound 4, half-maximal inhibitory concentration: 3800 nM
Beside the measured number, compound 4's estimate is 1.7-fold (0.23 log units) above it; the measured number falls inside the stated range.
By their numbers in this assay, from the lowest: compounds 4, 3 and 1 (each within the scatter of the next, the first and the last beyond it). At a limit, above all of these: compound 2.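

In this assay, the exchange of 4-chlorophenyl for 3,5-dichlorophenyl on a double-bonded chain carbon bound to a double-bonded ring carbon is the first single change that can be read among the compounds shown, and it amounts to a 1.7-fold lower number from compound 3 to compound 4 (0.22 log units; within the scatter). At this place on the shared core, then, the 3,5-dichlorophenyl group can stand in for the 4-chlorophenyl group without a step beyond the scatter, so the pair sets no order between the two groups. Nothing measured here speaks to why the step has this size.

From the compounds shown here alone, whether an amine or a carboxylic acid on this aryl ring, in place of the chlorine atoms, would give a step beyond the scatter remains open. Within the data shown here, it also remains open whether the same exchange would give a similar step with a different aryl group on the other side of the shared core, since this single pair is the only guide to the change so far.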